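Alkylidene hydantoin variant in the fluoronaphthyl pyridone series

The compounds below may be only part of what the source reports. "The series", "measured", "known", "first", "only" and "open" are said of these compounds alone.

Three compounds of the shared core have numbers in an assay on membranes from Chem-1 cells for displacement of a labelled ligand from prostaglandin E2 receptor EP3 subtype (Homo sapiens), read by scintillation counting, with a stated time of 2 h; on this read-out higher numbers stand for weaker inhibition and lower numbers for stronger inhibition. Compound 1 `CC(C)/C(=C1\C(=O)NC(=O)N1C)c1ccc(-c2ccc3cccc(F)c3c2)[nH]c1=O` gives 85 nM. Compound 2 `Cc1cc(C(/C=C2\OC(=O)NC2=O)C(C)C)c(=O)[nH]c1-c1ccc2cccc(F)c2c1` gives 23 nM. Compound 3 `CC(C)C(c1ccc(-c2ccc3cccc(F)c3c2)[nH]c1=O)C1C(=O)NC(=O)N1C` gives 46 nM, the second highest of the three numbers; its nearest neighbour is compound 1, a higher number within the scatter, and its furthest is compound 2, a lower number that is also within the scatter. On these data the three compounds cannot be ordered.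

Compound 4 `CC(C)C(/C=C1\NC(=O)NC1=O)c1ccc(-c2ccc3cccc(F)c3c2)[nH]c1=O` has not been measured in this assay. Relative to compound 3 the change is a group of 8 heavy atoms (4 carbon, 2 nitrogen, 2 oxygen; one five-membered non-aromatic ring with 2 hetero atoms) in place of a group of 8 heavy atoms (4 carbon, 2 nitrogen, 2 oxygen; one five-membered non-aromatic ring with 2 hetero atoms), on a saturated chain carbon bound to an aromatic carbon and a saturated chain carbon. The entering group carries one more double bond outside aromatic rings and one more hydrogen-bond donor than the group it replaces. For the measured compounds named here, no measured pair shows this change in isolation, so the size of the step is uncertain. Going by the values given here, compound 2, the one compound whose side group also has a double bond outside the ring leading to the heterocycle, gives 23 nM, and compound 4 is expected to land near that value. The step of a 1.5-fold lower number from compound 3 to compound 4 (0.19 log units; within the scatter) is therefore estimated to be a modest move toward a lower number, not clearly beyond the scatter. For compound 4 the expected value in this assay is 30 nM, with a range from 12 nM to 80 nM.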

Compound 4, inhibition constant: 43 nM
Compound 4: the middle estimate sits 1.4-fold (0.16 log units) below what was measured, within the range that was stated.
By their numbers in this assay, from the lowest: compounds 2, 4, 3 and 1 (each within the scatter of the next, the first and the last beyond it).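

For the compounds shown here, replacing 3-methyl-2,5-dioxoimidazolidin-4-yl on the saturated chain carbon gives the first one-place comparison in this set: in this assay, the step is a 1.1-fold lower number from compound 3 to compound 4 (0.03 log units; within the scatter). The two ring groups are therefore not separated at this position, even though the entering group has one more double bond outside aromatic rings and one more hydrogen-bond donor. No available evidence bears on the reason for this result.

The double bond and the additional donor change together here, so their separate contributions remain unresolved. Also open is whether a group outside this ring type, such as a carboxylic acid or a primary amide on the same saturated chain carbon, would give a number within the scatter of these compounds.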